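The compounds below may be only part of what the source reports. "The series", "measured", "known", "first", "only" and "open" are said of these compounds alone.

Measured so far:
- compound 2 `Brc1ccc(-n2cc(CSc3nc4ccccc4s3)nn2)cc1` — 75%
- compound 1 `Clc1ccc(-n2cc(CSc3nc4ccccc4s3)nn2)cc1` — 50%

In a functional assay on the whole organism (strain Albino Wistar) for inhibition, with Rattus norvegicus as the target, read by paw edema, with stated times of 1 h and 3 h, at a dose of 10 mg/kg by the oral route (a higher number here means more inhibition at the dose given (going by the name of the read-out), a lower number less inhibition), compound 2 stands highest of the two numbers. The nearest is compound 1, and the step of a number 25 percentage points higher from compound 1 to compound 2 (beyond the scatter) is the only one in hand; it is modest but lies beyond the scatter. Compound 3 `Cc1ccccc1-n1cc(CSc2nc3ccccc3s2)nn1` differs from compound 2 in one place: 2-methylphenyl in place of 4-bromophenyl on an aromatic nitrogen. Within the data shown here, no measured step exchanges a halogen for a methyl group, and none moves a substituent from the 4-position to the 2-position of the phenyl ring, so the one step bears only loosely on this change; it shows that the group on that ring does shift the read-out by a modest amount. A similarly sized move is therefore expected, most likely downward toward the value of compound 1. The estimate for compound 3 in this assay is 55% (from 35% to 75%), which means an expected step of a number 20 percentage points lower from compound 2 to compound 3 (beyond the scatter).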

Compound 3, a percentage reported as inhibition, in the whole organism at one dose (the size of the read-out at that dose, not a potency): 47.3%
The estimate for compound 3 lay 7.7 percentage points above the measured number, and the stated range covers the measured number.
By their numbers in this assay, from the lowest: compounds 3 and 1 (each within the scatter of the next); then compound 2.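

In this assay, 2-methylphenyl in place of 4-bromophenyl on the aromatic nitrogen gives a number 27.7 percentage points lower from compound 2 to compound 3 (beyond the scatter), so this replacement does not keep the high reading. The same group in place of 4-chlorophenyl gives a number 2.7 percentage points lower from compound 1 to compound 3 (within the scatter), so at this position a phenyl ring bearing methyl and no halogen cannot be told apart from 4-chlorophenyl, and among these three groups only 4-bromophenyl stands apart. Nothing available gives a reason for either step.

Compound 3 differs from compound 2 both in the substituent and in where it sits on the phenyl ring, and the compounds shown do not separate these two changes. Also open, going by these compounds, is how the read-out would respond to an amine or a carboxylic acid on that phenyl ring.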